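The source may hold more compounds than are shown below. What is called first, only, known or untested is meant among the compounds shown, and "the series" means these compounds.

Measured in a physicochemical assay for metabolic stability, read by LC-MS, in simulated gastric fluid, with a stated time of 15 min, tested at 50 uM; on this read-out lower numbers stand for a less stable compound and higher numbers for a more stable compound:
- compound 1 `Cc1ccn2c(C(=O)NCc3ccccc3Cl)c(C)nc2c1`: 97.2%
- compound 2 `CC(C)(C)OC(=O)c1coc(-c2ccccc2)n1`: "not determined" (no result reported)
- compound 3 `CCC(=O)c1ccccc1OC(=O)c1coc(-c2ccccc2)n1`: 1.8%

Compound 3 holds the lower of the two numbers available, and compound 1 lies above it by far more than the scatter. Compound 2 adds no number to the comparison.

Next is compound 4 `CCC(C)c1ccccc1OC(=O)c1coc(-c2ccccc2)n1`, with sec-butyl in place of propanoyl on an aromatic carbon. Within the data shown here, no measured pair sizes such a change. With compound 3 at 1.8%, little room remains for a fall, so a rise beyond the scatter in this assay is expected, though with wide uncertainty. The expected change is a number 18.2 percentage points higher from compound 3 to compound 4 (beyond the scatter). For compound 4 the estimated value is 20%, with an expected range of 2% to 75%.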

Compound 4, percent of the compound remaining: 0.2%
Estimate against measurement, compound 4: 19.8 percentage points above; measured number below the stated range.
By their numbers in this assay, from the lowest: compounds 4 and 3 (each within the scatter of the next); then compound 1.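

Within this assay the first sized step at this position, on an aromatic carbon ortho to a large group, is sec-butyl in place of propanoyl, which gives a number 1.6 percentage points lower from compound 3 to compound 4 (within the scatter) for this change. Losing the carbonyl and the hydrogen-bond acceptor of propanoyl therefore moves the read-out by no more than the usual scatter here. Nothing measured on these compounds accounts for this result.

Going by these compounds, whether an amine, a carboxylic acid or a longer chain at this aromatic carbon would move the read-out remains open. So does the effect of any change elsewhere on the shared core.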